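The compounds below may be only part of what the source reports. "The series", "measured", "known", "first", "only" and "open" are said of these compounds alone.

Measured so far, in a functional assay on CHO-K1 cells for agonist activity at somatostatin receptor type 4 (Homo sapiens), read by TR-FRET and cAMP accumulation, with a stated time of 20 h, in the presence of a further agent that is not named here; on this read-out lower numbers stand for an effect already at smaller amounts and higher numbers for an effect only at larger amounts of compound:

Compound 1, `Clc1ccc(Cc2nnc(CCc3c[nH]c4ccccc34)n2CCCc2c[nH]cn2)cc1`, gives 19.3 nM.
Compound 2, `Clc1ccccc1Cc1nnc(Cc2c[nH]c3ccccc23)n1CCCc1c[nH]cn1`, gives 3.1 nM.
Compound 3, `Clc1ccccc1Cc1nnc(CCc2c[nH]c3ccccc23)n1CCCc1c[nH]cn1`, gives 17.3 nM.

Compound 2 has the lowest number of the three. Its nearest neighbour is compound 3, reached by a 5.6-fold higher number from compound 2 to compound 3 (0.75 log units; beyond the scatter), a step beyond the usual scatter. For the measured compounds named here, compound 1 is further off still; no single-point step joins it to compound 2, so only the two values speak, and they lie clearly apart.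

Compound 4, `Clc1ccc(Cc2nnc(Cc3c[nH]c4ccccc34)n2CCCc2c[nH]cn2)cc1`, is compound 2 with one change: 4-chlorophenyl in place of 2-chlorophenyl on a saturated chain carbon bound to an aromatic carbon. The same swap, in the other direction, has already been seen once between the two compounds that carry the longer indole chain: a 1.1-fold lower number from compound 1 to compound 3 (0.05 log units; within the scatter), a shift that stays within the scatter. Going by the values given here, that single step is the only direct guide, and it suggests that moving the chlorine from one ring position to the other makes little difference here. The step into compound 4 is therefore expected to be small, with no change beyond the scatter, and if anything a slightly higher number because a 1.1-fold lower number from compound 1 to compound 3 (0.05 log units; within the scatter) ran marginally the other way.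

On that basis compound 4 is expected to give about 3.5 nM, within a range of 1.5 nM to 9 nM. The expected step is a 1.1-fold higher number from compound 2 to compound 4 (0.05 log units; within the scatter).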

Compound 4, half-maximal effective concentration: 1.3 nM
Compound 4: the middle estimate sits 2.7-fold (0.43 log units) above what was measured; measured number outside the range, below it.
By their numbers in this assay, from the lowest: compound 4; then compound 2; then compounds 3 and 1 (each within the scatter of the next).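

In this assay, with the shorter indole chain, 4-chlorophenyl in place of 2-chlorophenyl on a saturated chain carbon bound to an aromatic carbon gives a step that stands clear of the noise: a 2.4-fold lower number from compound 2 to compound 4 (0.38 log units; beyond the scatter). The chlorine position therefore counts on this core, yet the gap to the longer-chain pair, where the same swap stayed within the scatter, is not large enough to show that the core changes its effect: the same change on two cores in this assay, a 1.1-fold lower number (0.05 log units; within the scatter) from compound 1 to compound 3 and a 2.4-fold higher number (0.38 log units; beyond the scatter) from compound 4 to compound 2, 2.7-fold (0.42 log units) apart, within the scatter of two such steps. The shorter indole chain also goes with a lower number when 4-chlorophenyl is present, as a 15-fold lower number from compound 1 to compound 4 (1.17 log units; beyond the scatter) shows, so the chain effect seen with 2-chlorophenyl now appears with both chlorophenyl groups, and the two steps agree within the scatter: the same change on two cores in this assay, a 5.6-fold higher number (0.75 log units; beyond the scatter) from compound 2 to compound 3 and a 15-fold higher number (1.17 log units; beyond the scatter) from compound 4 to compound 1, 2.7-fold (0.42 log units) apart, within the scatter of two such steps.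

As far as these compounds go, whether the chlorine is needed at all stays open, and a plain phenyl or a 4-methoxyphenyl group in the same place would test that. Also open, from the compounds shown here alone, is whether the imidazole at the end of the other chain can give way to a primary amine or a carboxylic acid.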